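Ring nitrogen substituent and lipoxygenase inhibition

A few compounds are considered here, and "the series" means these few. Any claim that something is new, unique, unknown or untested is made for them only; others in the source may bear on it.

Compound 1 `COc1ccc2c(c1)c(CCCC(=O)N1CCOCC1)c(C)n2C(=O)c1ccc(Cl)cc1`: 70.2%
Compound 2 `Cc1c(CCCC(=O)N2CCOCC2)c2cc(Cl)ccc2n1Cc1ccc(Cl)cc1`: 37.9%

In an assay on cells for inhibition of Polyunsaturated fatty acid 5-lipoxygenase (Rattus norvegicus), tested at 5 uM (a lower number here means less inhibition, a higher number more inhibition at the concentration tested (going by the name of the read-out)), compound 1 gives 70.2% and compound 2 gives 37.9%. Compound 2 stands lowest of the two; its gap to compound 1 lies beyond the scatter. Compound 3 `Cc1[nH]c2ccc(Cl)cc2c1CCCC(=O)N1CCOCC1` has not been measured. The change from compound 2 to compound 3 is hydrogen in place of 4-chlorobenzyl on an aromatic nitrogen. Among the measured compounds shown here, no measured pair shows a step of this kind, so its size is unknown from the data. A further drop, beyond the scatter, is expected, a number 15.9 percentage points lower from compound 2 to compound 3 (beyond the scatter). Compound 3 is expected to give 22%, in a range from 5% to 45%.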

Compound 3, a percentage reported as inhibition, at one concentration (the size of the read-out at that concentration, not a potency): 71.3%
Compound 3: middle estimate off by 49.3 percentage points, on the low side, outside the stated range (above it).
By their numbers in this assay, from the lowest: compound 2; then compounds 1 and 3 (each within the scatter of the next).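

In this assay, hydrogen in place of 4-chlorobenzyl on the aromatic nitrogen gives a number 33.4 percentage points higher from compound 2 to compound 3 (beyond the scatter), the first step read at this position. In this pair, the large group is therefore not required for inhibition at the concentration tested, and its presence goes with the lower number. No measured property in hand bears on the reason for this step.

Going by these compounds, whether a methyl or an acetyl group on this nitrogen would track compound 2 or compound 3 remains open. So does whether an unsubstituted benzyl group would behave like 4-chlorobenzyl.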